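The source may hold more compounds than are shown below. What is called first, only, known or untested is meant among the compounds shown, and "the series" means these compounds.

Working notes on a small set of diesters sharing one core. Two members have been measured so far. Compound 1 `CCOC(=O)c1c(-c2c(Cl)c3cc(C)ccc3oc2=O)nn(-c2cccc(C)c2)c1C(=O)OCC` gives in a functional assay on HeLa cells (Homo sapiens) for cytotoxicity, read by MTT assay, with a stated time of 48 h (a higher number here means a weaker inhibitor, a lower number a stronger inhibitor), a value of 115000 nM. Among the measured compounds shown here, compound 2 `CCOC(=O)c1c(-c2cc3ccccc3oc2=O)nn(-c2cccc(C)c2)c1C(=O)OCC` gives in this assay a value of 245000 nM, the higher of the two numbers; its nearest neighbour is compound 1, and the gap between them lies beyond the usual scatter, so compound 2 is the weaker of the two measured members.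

Compound 3 `CCOC(=O)c1c(-c2cc3ccccc3oc2=O)nn(-c2ccc(Br)cc2)c1C(=O)OCC` is not yet measured. It differs from compound 2 in one place: 4-bromophenyl in place of 3-methylphenyl on an aromatic nitrogen. For the measured compounds named here, both measured compounds carry the same 3-methylphenyl on that aromatic nitrogen, so no measured pair shows what an exchange at this position does, and the step is judged without a precedent in the set. The expectation for compound 3 is a step from compound 2 of about a 1.3-fold lower number from compound 2 to compound 3 (0.11 log units; within the scatter), which is not beyond the scatter in either direction. Compound 3 is therefore estimated in this assay at 190000 nM, within a range from 80000 nM to 450000 nM.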

Compound 3, half-maximal inhibitory concentration: 250000 nM
Estimate against measurement, compound 3: 1.3-fold (0.12 log units) below; low and high end bracket the measured number.
By their numbers in this assay, from the lowest: compound 1; then compounds 2 and 3 (each within the scatter of the next).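

The exchange at the aromatic nitrogen can now be read, and in this assay 4-bromophenyl in place of 3-methylphenyl gives a 1.0-fold higher number from compound 2 to compound 3 (0.01 log units; within the scatter) so on the core of compound 2 this change leaves the number within the scatter. Among the compounds shown here, the two groups match in heavy atom count and both have one six-membered aromatic ring of carbon only with no hydrogen-bond donors or acceptors, so this single step shows only that this particular exchange at this position gives no readable change in this cytotoxicity read-out. No measurement bears on why the step is so small.

As far as these compounds go, it remains open whether a different kind of group on this nitrogen, such as a phenyl carrying a carboxylic acid or an amine, or a longer alkyl chain in place of the phenyl, would move the number beyond the scatter. From the compounds shown here alone, it is also open whether the same exchange would stay within the scatter on the core of compound 1, and whether the loss of the methyl and the gain of the bromine would each be silent when taken alone.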